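A few compounds are considered here, and "the series" means these few. Any claim that something is new, unique, unknown or untested is made for them only; others in the source may bear on it.

Compound 2 `c1ccc(CNCCCCN(C[C@H]2Cc3ccccc3CN2)[C@H]2CCCc3cccnc32)cc1` stands in a functional assay on cells for agonist activity at C-X-C chemokine receptor type 4 (Homo sapiens), read by fluorescence and calcium flux, with a stated time of 90 s (on this read-out higher numbers stand for an effect only at larger amounts of compound and lower numbers for an effect already at smaller amounts), only at the assay limit: compound 2 gives > 30000 nM, which is a limit and not a number. Compound 1 `c1ccc(CN(CCCCN(C[C@H]2Cc3ccccc3CN2)[C@H]2CCCc3cccnc32)Cc2ccccc2)cc1` likewise reaches only a limit in this assay, where compound 1 gives > 30000 nM. Compound 3 `FC1(F)CCC(NCc2ccc(CN(C[C@H]3Cc4ccccc4CN3)[C@H]3CCCc4cccnc43)cc2)CC1` too yields just a limit in this assay, compound 3 giving > 30000 nM. Among the compounds with values here, the one step between measured compounds, a step that the two limits leave unreadable from compound 1 to compound 2, cannot be read; both of its values are limits, so neither its size nor its direction is known.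

Compound 4 `CC(C)(CCN(C[C@H]1Cc2ccccc2CN1)[C@H]1CCCc2cccnc21)CNCC1CCOCC1` differs from compound 2 by a group of 12 heavy atoms (10 carbon, 1 nitrogen, 1 oxygen; one six-membered non-aromatic ring with 1 hetero atom) in place of a group of 10 heavy atoms (9 carbon, 1 nitrogen; one six-membered aromatic ring of carbon only), on a saturated chain carbon, two bonds along the chain from an amine nitrogen. No measured step bears directly on this change, and the single step shown gives no readable size. What the measurements do show is the limit of > 30000 nM in this assay, at which 3 of the 3 values shown sit, with nothing among them pointing to an effect below that limit. Compound 4 is therefore expected to give about 30000 nM in this assay, estimated to lie between 8000 nM and 100000 nM. The estimated step of a number no higher from compound 2 to compound 4 (the limit leaves the size open) is expected to stay within the scatter.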

Compound 4, half-maximal effective concentration: > 30000 nM
Compound 4: a limit, no number (the forecaster's own chance of this, stated with the estimate: 80%); the middle value sits exactly at the limit.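

No new step can be read: compound 2 and compound 4 both stand only at a limit in this assay, so the change between them has no readable size. The compounds shown leave open what would give a real number, for they show only this: the limit of > 30000 nM in this assay, at which 4 of the 4 values shown sit.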